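This account rests on a few compounds, and the source may have more. Where it says the series, first, only, none or still open, it means among the compounds named here.

In a functional assay on HL-60 cells (Homo sapiens) for antiproliferative activity, with a stated time of 24 h (a lower number here means a stronger inhibitor, a higher number a weaker inhibitor), compound 2 `NC(=O)c1c(NC(=O)c2ccccc2Cl)sc2c1CCN(Cc1ccccc1Cl)C2` gives 2900 nM, the lowest of the two numbers on hand. Compound 1 `NC(=O)c1c(NC(=O)c2ccccc2Cl)sc2c1CCNC2` gives 18600 nM, and the step of a 6.4-fold lower number from compound 1 to compound 2 (0.81 log units; beyond the scatter) shows that placing a 2-chlorobenzyl on an amine nitrogen in a ring lowers the number. Compound 3 `NC(=O)c1c(NC(=O)c2ccccc2Cl)sc2c1CCN(Cc1ccc([N+](=O)[O-])cc1)C2` differs from compound 2 by 4-nitrophenyl in place of 2-chlorophenyl on a saturated chain carbon bound to an amine nitrogen in a ring. Within the data shown here, no measured step changes the substituent on that benzyl group, so the only step on hand does not speak to this exchange. The expected step is no change at the digits printed from compound 2 to compound 3 (within the scatter), within the scatter. Compound 3 is therefore estimated at 2900 nM, between 1000 nM and 9000 nM.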

Compound 3, half-maximal inhibitory concentration: 11400 nM
Beside the measured number, compound 3's estimate is 3.9-fold (0.59 log units) below it; the whole stated range lies below it.
By their numbers in this assay, from the lowest: compound 2; then compounds 3 and 1 (each within the scatter of the next).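

In this assay the substituent on the benzyl group at the ring amine nitrogen turns out to matter: 4-nitrophenyl in place of 2-chlorophenyl gives a 3.9-fold higher number from compound 2 to compound 3 (0.59 log units; beyond the scatter) and so takes back much of what the 2-chlorobenzyl group had brought. The step of a 1.6-fold lower number from compound 1 to compound 3 (0.21 log units; within the scatter) puts 4-nitrobenzyl in place of hydrogen, so a benzyl group at this nitrogen does not by itself secure the lower number of compound 2. Nothing on hand explains the difference between the two benzyl groups. As far as these compounds go, because the group and its ring position change together here, it stays open how 4-chlorobenzyl or 2-nitrobenzyl would read. Plain benzyl, the reference for both groups, also stays open.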